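The compounds below may be only part of what the source reports. "The series", "measured", "known", "first", "only" and "open" are said of these compounds alone.

Among the measured compounds shown here, in a functional assay on KB cells (Homo sapiens) for cytotoxicity (a lower number here means a stronger inhibitor, a higher number a weaker inhibitor), compound 2 (`COc1ccc(C(=O)Nc2cccc3c2N(S(=O)(=O)c2ccc(OC)cc2)CC3)cc1`) gives 2600 nM as the higher of the two numbers measured so far. For the measured compounds named here, the only other measured compound, compound 1 (`COc1ccc(S(=O)(=O)N2CCc3cccc(NC(=O)c4ccc([N+](=O)[O-])cc4)c32)cc1`), gives 102 nM as the lower one. Compound 3 (`COc1ccc(S(=O)(=O)N2CCc3cccc(NC(=O)N(C)c4ccccc4)c32)cc1`), not yet measured, carries methyl(phenyl)amino in place of 4-methoxyphenyl on a carbonyl carbon. Going by the values given here, only one measured step bears on this change (a 25-fold higher number from compound 1 to compound 2 (1.41 log units; beyond the scatter)). It is a large step, made by methoxy in place of nitro on an aromatic carbon, and it shows that the numbers in this assay can move strongly within this small set. Among the compounds with values here, it is a different change, however, and no measured pair tests the present one. The estimated step (a 1.7-fold lower number from compound 2 to compound 3 (0.24 log units; within the scatter)) is therefore expected to be modest, toward a lower number, with wide uncertainty in both directions. Compound 3 is expected at 1500 nM with an estimated range from 200 nM to 8000 nM around that middle.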

Compound 3, half-maximal inhibitory concentration: > 10000 nM
Compound 3: a limit, no number; the forecaster's own chance of this, stated with the estimate: 12%; middle value at least 6.6-fold (0.82 log units) away from the limit.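

In this assay compound 3 gives a limit of the assay, not a number: the limit of > 10000 nM in this assay, at which 1 of the 3 values shown sits. Methyl(phenyl)amino in place of 4-methoxyphenyl on the carbonyl carbon gives an at least 3.8-fold higher number from compound 2 to compound 3 (0.58 log units; beyond the scatter), so at this position the outcome changes beyond the scatter even though the group entering and the group leaving each carry one six-membered aromatic ring of carbon only. The same group in place of 4-nitrophenyl gives an at least 98-fold higher number from compound 1 to compound 3 (1.99 log units; beyond the scatter), which shows that replacing the whole group on this carbonyl carbon can matter, whereas the earlier pair showed only a change on the aromatic ring.

As far as these compounds go, how far the true number of compound 3 lies past its limit remains open. From the compounds shown here alone, it also remains open whether phenylamino, without the methyl, or 4-aminophenyl would stand nearer compound 1 or compound 3.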